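A few compounds are considered here, and "the series" means these few. Any claim that something is new, unique, unknown or untested is made for them only; others in the source may bear on it.

Measured so far in a toxicity assay on HUVEC cells (Homo sapiens) for inhibition; a higher number here means a weaker inhibitor of growth, a lower number a stronger inhibitor of growth:
- compound 1, `COc1cc(OC)cc(N2CCN(C(=O)c3oc(C)nc3-c3cccc(F)c3)CC2)c1`, 0.126 ug/mL
- compound 2, `Cc1nc(-c2ccccc2)c(C(=O)N2CCN(c3cccc(C)c3C)CC2)o1`, 0.38 ug/mL

Compound 2 holds the higher of the two numbers shown. Its nearest neighbour is compound 1, whose lower value lies beyond the usual scatter of the measurement, so on these two points compound 2 is the weaker inhibitor of growth. Within the data shown here, the two compounds differ in more than one place, so no single step between them is counted.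

Compound 3, `Cc1nc(-c2ccccc2)c(C(=O)N2CCN(c3cccc(F)c3)CC2)o1`, has not yet been measured. It is reached from compound 2 by one change: 3-fluorophenyl in place of 2,3-dimethylphenyl on an amine nitrogen in a ring. Two methyl groups leave the phenyl on the ring nitrogen and a single fluorine enters on the phenyl in their place; the rest of the molecule, including the shared core, is unchanged.

Among the measured compounds shown here, no measured step isolates this kind of swap, so the expectation rests on the size of the change alone. A step of modest size, if any, is expected for a 1.3-fold lower number from compound 2 to compound 3 (0.10 log units; within the scatter), most likely none beyond the scatter. For compound 3 the estimated value in this assay is 0.3 ug/mL, with a range from 0.1 ug/mL to 0.9 ug/mL.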

Compound 3, concentration for 50% growth inhibition: 1.05 ug/mL
The estimate for compound 3 lay 3.5-fold (0.54 log units) below the measured number; the whole stated range lies below it.
By their numbers in this assay, from the lowest: compound 1; then compound 2; then compound 3.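

In this assay, among these compounds, the swap of 2,3-dimethylphenyl for 3-fluorophenyl on the amine nitrogen in the ring gives a 2.8-fold higher number from compound 2 to compound 3 (0.44 log units; beyond the scatter) and is the first single-place step, with the shared core held constant. This position is therefore not silent: the group on that nitrogen can move the number beyond the scatter, and here the change runs towards a weaker inhibitor of growth, even though the two groups match in hydrogen-bond donors, hydrogen-bond acceptors and net charge and differ only slightly in size, with 8 heavy atoms leaving and 7 entering. No measurement is at hand that bears on why the number moves.

The swap removes two methyl groups and adds a fluorine in one step, so the share of each in the shift remains unresolved. Unsubstituted phenyl, 3-methylphenyl or 2-methylphenyl on the same nitrogen would separate these contributions, and a single step cannot show whether the trend holds with other groups there, such as 3-methoxyphenyl.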